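Replacing a dichlorophenyl amide with a methylphenyl amide

The source may report more compounds than this note shows. Statements on the series, on what has been measured and on what is new or still open speak of the compounds shown alone.

Compound 1 `CN(C)c1nc(N[C@H]2CC[C@@H](NC(=O)c3ccc(Cl)c(Cl)c3)CC2)nc2ccccc12` was tested in an assay on HEK293 cells for inhibition of melanin-concentrating hormone receptor 1 (Homo sapiens), read by radioligand binding (on this read-out higher numbers stand for weaker inhibition and lower numbers for stronger inhibition), and gives 5 nM. Two other compounds with the same core were measured alongside it. Compound 2 `CN(C)c1nc(NCC2CCC(CNCc3ccc(Br)cc3OC(F)(F)F)CC2)nc2ccccc12` gives 960 nM in this assay, and compound 3 `CN(C)c1nc(N[C@H]2CC[C@@H](NS(=O)(=O)c3ccc(Br)cc3OC(F)(F)F)CC2)nc2ccccc12` gives 83 nM. Compound 1 therefore stands at the lowest number of the three, meaning the strongest inhibition; its nearest neighbour on the numbers is compound 3, and the gap to compound 2 is wider still, both gaps lying beyond the scatter of repeated measurements.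

Compound 4 `Cc1cccc(C(=O)N[C@H]2CC[C@@H](Nc3nc(N(C)C)c4ccccc4n3)CC2)c1` differs from compound 1 in a single place: 3-methylphenyl in place of 3,4-dichlorophenyl on a carbonyl carbon. Going by the values given here, no measured pair in this set shows this exact change, so its effect can only be anticipated. The group that leaves carries two chlorines, the group that enters carries one methyl, and the rest of the molecule is untouched. The step from compound 1 to compound 4 is expected to run toward weaker inhibition, with an expected size of a 6.0-fold higher number from compound 1 to compound 4 (0.78 log units; beyond the scatter), beyond the scatter but not approaching the distance to compound 2. Compound 4 is accordingly expected to give 30 nM in this assay, with a likely range from 8 nM to 150 nM.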

Compound 4, half-maximal inhibitory concentration: 4.6 nM
For compound 4 the middle estimate is 6.5-fold (0.81 log units) above the measured one; measured number below the stated range.
By their numbers in this assay, from the lowest: compounds 4 and 1 (each within the scatter of the next); then compound 3; then compound 2.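

In this assay, 3-methylphenyl in place of 3,4-dichlorophenyl on a carbonyl carbon gives a 1.1-fold lower number from compound 1 to compound 4 (0.04 log units; within the scatter), so this read-out does not separate the two compounds. Going by these compounds alone, this is the first step in the set that changes only one place, and it shows that, on this amide and with the rest of the molecule untouched, the two chlorines are not needed for a number this low: a ring carrying one methyl reads the same within the scatter. The data offer no evidence on why these two groups read alike.

This single pair cannot show how much else this position would accept, such as a plain phenyl ring carrying neither chlorine nor methyl, or a phenyl ring bearing an amine or a carboxylic acid. Compound 2 and compound 3 each differ from compound 1 in more than one place, so they cannot show separately what the amide carbonyl or the ring attached to it contributes.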